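The source may report more compounds than this note shows. Statements on the series, on what has been measured and on what is new or still open speak of the compounds shown alone.

Working notes on the series. Going by the values given here, compound 1 (`Cc1ccc(C)c(N2CCN(C(=O)c3oc(C)nc3-c3ccccc3)CC2)c1`) gives 1.4% in an ADME assay on microsomes from liver (Mus musculus) for metabolic stability, read by LC-MS, with a stated time of 1 h, tested at 5 uM (on this read-out lower numbers stand for a less stable compound and higher numbers for a more stable compound), and holds the lower of the two numbers so far. Compound 2 (`COc1cc(OC)cc(N2CCN(C(=O)c3oc(C)nc3-c3cccc(F)c3)CC2)c1`) gives 11.6% and stands higher than compound 1 by more than the usual scatter. These two compounds differ in more than one place, so their gap cannot be assigned to any single change.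

Compound 3 (`Cc1nc(-c2ccccc2)c(C(=O)N2CCN(c3cccc(C#N)c3)CC2)o1`) is still unmeasured. Its change from compound 1 is 3-cyanophenyl in place of 2,5-dimethylphenyl on an amine nitrogen in a ring and amounts to 3-cyanophenyl in place of 2,5-dimethylphenyl on an amine nitrogen in a ring, with the rest of the core of compound 1 kept. Among the compounds with values here, no measured pair isolates a swap at this place, so the size of the step is a judgement. Little room exists downward because compound 1 stands at 1.4% on this scale. A modest rise is therefore expected, of a size near the scatter, and the estimated step is a number 7.6 percentage points higher from compound 1 to compound 3 (within the scatter) in this assay for now. For compound 3 the expected value is 9% with an estimated range from 2% to 28% as the working figure.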

Compound 3, percent of the compound remaining: 1.6%
Compound 3: middle estimate off by 7.4 percentage points, on the high side; measured number outside the range, below it.
By their numbers in this assay, from the lowest: compounds 1, 3 and 2 (each within the scatter of the next, the first and the last beyond it).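

In this assay, going by these compounds alone, the pair of compound 1 and compound 3 is the first to isolate a swap at this place, and 3-cyanophenyl in place of 2,5-dimethylphenyl on an amine nitrogen in a ring gives a number 0.2 percentage points higher from compound 1 to compound 3 (within the scatter) with the rest of the core of compound 1 kept. The count of 8 heavy atoms stays the same while the nitrile brings 1 hydrogen-bond acceptor and a triple bond into the group, yet on this read-out the two compounds cannot be told apart, and both sit close to the bottom of the scale. No measured evidence is available that would account for this outcome.

Still open, as far as these compounds go, is whether any group at this place can lift the number clear of the bottom of the scale, for example a phenyl ring carrying a carboxylic acid or an amine, or a saturated ring in place of the phenyl ring. The compounds shown also offer no single-place comparison for the other parts of the shared core, so the sites that govern the number in this assay remain unassigned.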